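Halogen position on the triazole benzyl and growth inhibition

The source may hold more compounds than are shown below. What is called first, only, known or untested is meant among the compounds shown, and "the series" means these compounds.

In a functional assay on MIA PaCa-2 cells (Homo sapiens) for inhibition, read by MTT assay, with a stated time of 48 h, tested at 10 uM (a higher number here means more inhibition of growth at the concentration tested, a lower number less inhibition of growth), compound 3 `O=C(/C=C/c1ccc(OCc2cn(Cc3ccc(Br)cc3)nn2)cc1)c1ccc(Br)cc1` gives 29%, the lowest of the three measured values. Compound 1 `O=C(/C=C/c1ccc(OCc2cn(Cc3ccccc3Br)nn2)cc1)c1ccc(Br)cc1` gives 43% and compound 2 `O=C(/C=C/c1ccc(OCc2cn(Cc3cccc(Br)c3)nn2)cc1)c1ccc(Br)cc1` gives 43%; the step of no change at the digits printed from compound 1 to compound 2 (within the scatter) stays within the scatter, whereas a number 14 percentage points lower from compound 1 to compound 3 (beyond the scatter) and a number 14 percentage points lower from compound 2 to compound 3 (beyond the scatter) both lie beyond it. Compound 4 `O=C(/C=C/c1ccc(OCc2cn(Cc3ccccc3F)nn2)cc1)c1ccc(Br)cc1` differs from compound 3 by 2-fluorophenyl in place of 4-bromophenyl on a saturated chain carbon bound to an aromatic nitrogen. The step of a number 14 percentage points lower from compound 1 to compound 3 (beyond the scatter) bears on this, since it exchanged 2-bromophenyl for 4-bromophenyl; reversing that exchange suggests a modest gain. Going by the values given here, no measured step shows fluorine in place of bromine, so that part of the change has no anchor. Compound 4 is therefore expected near 40%, within 25% to 55%. The expected step is a number 11 percentage points higher from compound 3 to compound 4 (beyond the scatter).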

Compound 4, percent growth inhibition at one concentration: 28%
Beside the measured number, compound 4's estimate is 12 percentage points above it, within the range that was stated.
By their numbers in this assay, from the lowest: compounds 4 and 3 (each within the scatter of the next); then compounds 1 and 2 (each within the scatter of the next).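

Fluoro in place of bromo on an aromatic carbon now has a direct step, and it is not silent: a number 15 percentage points lower from compound 1 to compound 4 (beyond the scatter) in this assay. The 2-fluorophenyl group also falls short of the 3-bromophenyl group, with a number 15 percentage points lower from compound 2 to compound 4 (beyond the scatter), yet it stays level with the 4-bromophenyl group, with a number 1 percentage points lower from compound 3 to compound 4 (within the scatter), so a low reading here arises with either halogen. No measurement at hand gives a reason for this. Left open is whether chloro on the same aromatic carbon would read with the bromo or the fluoro compounds, and whether an amine on this ring would shift growth inhibition at all.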